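The compounds below may be only part of what the source reports. "The series", "measured", "known", "first", "only" and "open" are said of these compounds alone.

Working notes on the series. For the measured compounds named here, in an ADME assay on the whole organism (Mus musculus) for pharmacokinetics, at a dose of 10 mg/kg by the oral route (a lower number here means less compound in the circulation, a higher number more compound in the circulation at the dose given), compound 1 (`CN(Cc1ccccc1)S(=O)(=O)c1ccc(NC(=O)NCc2ccncc2)cc1`) gives 4510 ng.h/mL, the lowest of the three numbers measured so far. Compound 2 (`O=C(NCc1cn[nH]c1)Nc1ccc(S(=O)(=O)c2ccccc2)cc1`) lies nearest at 9340 ng.h/mL, a gap just beyond the usual scatter, and compound 3 (`O=C(NCc1cnco1)Nc1ccc(S(=O)(=O)c2cccc(OC(F)(F)F)c2)cc1`) lies furthest at 45200 ng.h/mL. Going by the values given here, no two of these measured compounds differ in one place only, so no measured step bears directly on the next comparison.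

Compound 4 (`O=C(NCc1ccncc1)Nc1ccc(S(=O)(=O)N2CCc3ccccc3C2)cc1`) has not yet been measured. It carries 1,2,3,4-tetrahydroisoquinolin-2-yl in place of benzyl(methyl)amino on a sulfonyl sulfur. The rest of compound 1 stays as it is. Both groups hold one six-membered aromatic ring of carbon only and no net charge, and the entering group adds one six-membered non-aromatic ring with 1 hetero atom.

Among the compounds with values here, with no measured precedent for this change, the working expectation is no step beyond the scatter in this assay. The estimate is a small step, a 1.1-fold higher number from compound 1 to compound 4 (0.04 log units; within the scatter), and it is expected to stay within that scatter. The numbers in this small set run from compound 1 at 4510 ng.h/mL to compound 3 at 45200 ng.h/mL, which argues for a wide range. For compound 4 the expected value is 5000 ng.h/mL, with an estimated range of 1500 ng.h/mL to 16000 ng.h/mL.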

Compound 4, area under the concentration-time curve: 4270 ng.h/mL
Beside the measured number, compound 4's estimate is 1.2-fold (0.07 log units) above it; the range from low to high includes it.
By their numbers in this assay, from the lowest: compounds 4 and 1 (each within the scatter of the next); then compound 2; then compound 3.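

In this assay, 1,2,3,4-tetrahydroisoquinolin-2-yl in place of benzyl(methyl)amino on a sulfonyl sulfur gives a 1.1-fold lower number from compound 1 to compound 4 (0.02 log units; within the scatter), so the two compounds cannot be told apart by this read-out. For the compounds shown here, this is the first measured comparison that differs in one place only, and it shows that adding the six-membered non-aromatic ring with 1 hetero atom, with the rest of compound 1 unchanged, produces no step beyond the scatter. No supporting measurement is available to explain this outcome.

Going by these compounds alone, the pair covers only two groups at this place, both carrying a six-membered aromatic ring of carbon only and no net charge, so it remains open whether a morpholine ring, a primary amine or a carboxylic acid on the sulfonyl sulfur would also give a number in the same range. Compound 2 and compound 3 each differ from compound 1 in more than one place, so the shown compounds do not assign their numbers to any single part of the structure.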